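Methylsulfanyl for Fluoro in a Quinoline Urea Series

The source may report more compounds than this note shows. Statements on the series, on what has been measured and on what is new or still open speak of the compounds shown alone.

Compound 1 `Cc1cc(NC(=O)Nc2ccccc2C(F)(F)F)c2ccccc2n1` gives > 25000 nM in an ADME assay on HepG2 cells (Homo sapiens) for cytotoxicity, with a stated time of 72 h (on this read-out higher numbers stand for an effect only at larger amounts of compound and lower numbers for an effect already at smaller amounts), which is a limit of the assay and not a number.
Compound 2 `Cc1ccc(NC(=O)Nc2cc(C)nc3ccccc23)cc1` gives > 25000 nM in this assay, again a limit.
Compound 3 `Cc1cc(NC(=O)Nc2ccccc2F)c2ccccc2n1` gives > 25000 nM in this assay, once more a limit.

Compound 3 therefore stands at a limit, and the two other values shown sit at that same limit: the limit of > 25000 nM in this assay, at which 3 of the 3 values shown sit, gathers all three. Both measured steps, a step that the two limits leave unreadable from compound 1 to compound 3 and a step that the two limits leave unreadable from compound 2 to compound 3, join one limit to another, so their size cannot be read and neither shows a direction.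

Compound 4 `CSc1ccccc1NC(=O)Nc1cc(C)nc2ccccc12` differs from compound 3 by methylsulfanyl in place of fluoro on an aromatic carbon. For the measured compounds named here, no measured step bears on this change with a readable size, and the only evidence is the limit of > 25000 nM in this assay, at which 3 of the 3 values shown sit, where every compound measured so far stands. The expectation for compound 4 is thus that it too reaches the limit rather than a number, and its estimated value is 25000 nM, within a range from 10000 nM to 60000 nM. The step of a number no higher from compound 3 to compound 4 (the limit leaves the size open) is expected to be none beyond the usual scatter.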

Compound 4, half-maximal effective concentration: > 25000 nM
Compound 4: only a limit was reported; the forecaster's own chance of this, stated with the estimate: 80%; the middle value sits exactly at the limit.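

Compound 4 gives a limit of the assay and not a number, so the steps linking it to compound 1 and compound 3 cannot be read: the limit of > 25000 nM in this assay, at which 4 of the 4 values shown sit.

The compounds shown leave open how methylsulfanyl, fluoro and trifluoromethyl compare in this assay, as none of them has yet given a number there.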